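The compounds below may be only part of what the source reports. "The series", "measured", "known", "first", "only" and "open" are said of these compounds alone.

Compound 1 `COc1ccccc1Nc1nc(-c2cccc(F)c2)nc2ccc(F)cc12` is the starting point of this account. In a functional assay on HT29-AK cells (Homo sapiens) for cytotoxicity, read by MTT assay, with a stated time of 48 h (on this read-out lower numbers stand for stronger inhibition and higher numbers for weaker inhibition), compound 1 gives only a limit of the assay, > 50000 nM, and no number. Compound 2 `Fc1cccc(-c2nc(Nc3cccc(Cl)c3)c3cc(F)ccc3n2)c1` likewise stops at a limit in this assay, > 50000 nM. Compound 3 `Fc1cccc(-c2nc(Nc3ccccc3Cl)c3cc(F)ccc3n2)c1` too returns only a limit in this assay, > 50000 nM. Because all three sit at the same limit (the limit of > 50000 nM in this assay, at which 3 of the 3 values shown sit), none of the steps among them can be read: the change from compound 1 to compound 2 gives a step that the two limits leave unreadable from compound 1 to compound 2, that from compound 1 to compound 3 gives a step that the two limits leave unreadable from compound 1 to compound 3, and that from compound 2 to compound 3 gives a step that the two limits leave unreadable from compound 2 to compound 3.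

The compound not yet measured is compound 4 `Nc1cccc(Nc2nc(-c3cccc(F)c3)nc3ccc(F)cc23)c1`. It differs from compound 1 in one place: 3-aminophenyl in place of 2-methoxyphenyl on a nitrogen on an aromatic ring. Among the measured compounds shown here, no measured step bears on this change in a readable way, since every value so far is a limit, so nothing in the numbers points to a gain or a loss in this assay.

On that basis compound 4 is expected to remain near the limit as well, with an estimated step from compound 1 of a step that the limit leaves unreadable from compound 1 to compound 4. The estimate for compound 4 in this assay is 60000 nM, within a range from 15000 nM to 250000 nM.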

Compound 4, half-maximal inhibitory concentration: > 50000 nM
Compound 4: no number, only a limit; the forecaster's own chance of this, stated with the estimate: 75%; the middle value is on the limit's open side.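

In this assay compound 4 also returns only a limit, > 50000 nM, so its steps from compound 1, compound 2 and compound 3 cannot be read: the limit of > 50000 nM in this assay, at which 4 of the 4 values shown sit. The compounds shown leave open whether any of these groups on the nitrogen changes the result in this assay, and no compound here yields an actual number.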